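From a diethylamino chain to a dibutylamino chain

A few compounds are considered here, and "the series" means these few. Any claim that something is new, unique, unknown or untested is made for them only; others in the source may bear on it.

Measured in a functional assay on PC-3 cells (Homo sapiens) for antiproliferative activity, read by WST assay, with a stated time of 3 days; a lower number here means a stronger inhibitor, a higher number a weaker inhibitor:
- Compound 1 `COc1cc(-c2oc3ccccc3c(=O)c2OC(C)C)cc(OC)c1OC` gives 21200 nM
- Compound 2 `CCC(C)Oc1c(-c2cc(OC)c(OC)c(OC)c2)oc2ccccc2c1=O` gives 38600 nM
- Compound 3 `CCN(CC)CCCOc1c(-c2cc(OC)c(OC)c(OC)c2)oc2ccccc2c1=O` gives 13600 nM

Compound 3 cannot be separated from one neighbour, with a 1.6-fold lower number from compound 1 to compound 3 (0.19 log units; within the scatter), but it does clear the other, with a 2.8-fold lower number from compound 2 to compound 3 (0.45 log units; beyond the scatter). Compound 4 `CCCCN(CCCC)CCCCOc1c(-c2cc(OC)c(OC)c(OC)c2)oc2ccccc2c1=O` alters the chain on the oxygen of compound 3: (dibutylamino)methyl in place of diethylamino on a saturated chain carbon, three bonds along the chain from an oxygen on an aromatic ring. Within the data shown here, no measured step changes this chain itself. The closest evidence is those same two steps, which put 3-(diethylamino)propyl in place of isopropyl or sec-butyl: one within the scatter, one modest. A modest move to a lower number is therefore expected in this assay, an estimated 2.3-fold lower number from compound 3 to compound 4 (0.36 log units; beyond the scatter). Compound 4 is estimated at 6000 nM, with an expected range of 1800 nM to 20000 nM.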

Compound 4, half-maximal inhibitory concentration: 5300 nM
For compound 4 the middle estimate is 1.1-fold (0.05 log units) above the measured one; low and high end bracket the measured number.
By their numbers in this assay, from the lowest: compound 4; then compounds 3, 1 and 2 (each within the scatter of the next, the first and the last beyond it).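

Among these compounds, the step shows a 2.6-fold lower number from compound 3 to compound 4 (0.41 log units; beyond the scatter) in this assay and is the first one made within the amine chain itself. Here (dibutylamino)methyl, with 10 heavy atoms, replaces diethylamino, with 5, and the larger group brings a modest gain rather than a loss. Nothing available explains this gain.

On these data alone, this single step lengthens the chain and enlarges the groups on the nitrogen together, so the share of each remains open. A dibutylamino group on the shorter chain of compound 3 would separate those two changes, and a carboxylic acid in place of the amine would ask whether the amine matters at all.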